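A few compounds are considered here, and "the series" means these few. Any claim that something is new, unique, unknown or untested is made for them only; others in the source may bear on it.

Working notes on the series. Compound 1 `Cc1ccccc1-c1cc(NCc2cncn2Cc2ccc(-c3ccccc3)cc2)ccc1-c1nc2ccccc2s1` and compound 3 `Cc1cccc(-c2cc(NCc3cncn3Cc3ccc(-c4ccccc4)cc3)ccc2-c2nc3ccccc3s2)c1C` share one core; compound 2 `c1ccc(Cn2cncc2CNc2cccc(-c3ccccc3)c2)cc1` is built on a second core, and the difference between the two cores is not broken down here. Compound 4 `Cc1ccc(Cn2cncc2CNc2cccc(-c3ccccc3)c2)cc1` has not yet been measured.

In a toxicity assay on NIH3T3 cells (Mus musculus) for cytotoxicity, read by resazurin assay (on this read-out higher numbers stand for an effect only at larger amounts of compound and lower numbers for an effect already at smaller amounts), compound 1 gives > 1000 nM, which is a limit of the assay and not a number. In this assay compound 3 gives > 1000 nM, again a limit. In this assay compound 2 gives > 750 nM, also a limit. Thus two of the three values sit at the limit of > 1000 nM in this assay, at which 2 of the 3 values shown sit, and one at the limit of > 750 nM in this assay, at which 1 of the 3 values shown sits.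

Compound 3 differs from compound 1 by methyl in place of hydrogen on an aromatic carbon. The step that the two limits leave unreadable from compound 1 to compound 3 cannot be sized, since both values are limits.

Compound 4 differs from compound 2 by methyl in place of hydrogen on an aromatic carbon. This is the same kind of change as that from compound 1 to compound 3, not the same: in compound 3 the methyl enters ortho to a methyl group and meta to a large group, whereas in compound 4 it enters para to a large group.

For compound 4 the expectation in this assay is 2000 nM, most likely again reported only as a limit, with a range from 750 nM to 10000 nM. This rests on compound 2 sitting at the limit of > 750 nM in this assay, at which 1 of the 3 values shown sits, and on the unreadable step that the two limits leave unreadable from compound 1 to compound 3 for the same kind of change. The expected step is a step that the limit leaves unreadable from compound 2 to compound 4.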

Compound 4, half-maximal effective concentration: 10000 nM
Compound 4: the middle estimate sits 5.0-fold (0.70 log units) below what was measured; the measured number falls inside the stated range.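

In this assay compound 2 gives > 750 nM, which is a limit of the assay and not a number. Among the compounds shown here, the step from compound 2 to compound 4 therefore cannot be read, and no new step comes from this result. The compounds shown leave open how large a change methyl in place of hydrogen on an aromatic carbon brings in this assay, on either core.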